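The source may report more compounds than this note shows. Statements on the series, on what has been measured and on what is new or still open speak of the compounds shown alone.

In a functional assay on KYSE-410 cells (Homo sapiens) for antiproliferative activity, read by MTT assay, with a stated time of 72 h (a higher number here means a weaker inhibitor, a lower number a stronger inhibitor), compound 1 `COc1cccc(NC(=O)c2cc(=O)[nH]c3cc(Br)ccc23)c1` reads > 20000 nM, which is a limit and not a number. Going by the values given here, compound 2 `COc1ccc(-c2ccc3c(C(=O)Nc4cccc(F)c4)cc(=O)[nH]c3c2)cc1` gives 18000 nM in this assay, the only actual number so far, so it cannot yet be ranked against a second measured value. Among the compounds with values here, no measured pair differs in one place, which leaves no direct guide to the size of the next step.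

Compound 3 `O=C(Nc1cccc(F)c1)c1cc(=O)[nH]c2cc(C3=CCOCC3)ccc12`, not yet measured, differs from compound 2 on an aromatic carbon: the 4-methoxyphenyl leaves and a non-aromatic six-membered ring with one hetero atom enters, (a group of 6 heavy atoms (5 carbon, 1 oxygen; one six-membered non-aromatic ring with 1 hetero atom) in place of a group of 8 heavy atoms (7 carbon, 1 oxygen; one six-membered aromatic ring of carbon only), on an aromatic carbon).

With compound 2 at 18000 nM as the sole numerical anchor, no change beyond the scatter is expected in this assay, and no direction is favoured with any confidence. The expected size of the change is a 1.1-fold higher number from compound 2 to compound 3 (0.05 log units; within the scatter). Compound 3 is estimated at 20000 nM, with an expected range of 9000 nM to 40000 nM.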

Compound 3, half-maximal inhibitory concentration: 12100 nM
For compound 3 the middle estimate is 1.7-fold (0.22 log units) above the measured one; measured number inside the range.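

Setting the non-aromatic six-membered ring with one hetero atom in place of the 4-methoxyphenyl gives, in this assay, a 1.5-fold lower number from compound 2 to compound 3 (0.17 log units; within the scatter). This first single-place step in the series shows that, on this aromatic carbon, an aromatic ring of carbon only can give way to a smaller non-aromatic ring carrying a double bond without a change beyond the scatter. The step offers no route to a clearly stronger compound, and the series still stands close to a limit of the read-out, which is a limit and not a number: the limit of > 20000 nM in this assay, at which 1 of the 3 values shown sits.

On these data alone, whether an amine or a carboxylic acid on this aromatic carbon would move the number beyond the scatter stays open. So does the outcome of removing the double bond from the entering ring.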